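A few compounds are considered here, and "the series" means these few. Any claim that something is new, unique, unknown or untested is made for them only; others in the source may bear on it.

The study begins with compound 1 `O=C(c1ccccc1)c1ccc2c(c1)oc(=O)n2C(=O)NCCCCc1ccccc1`. Among the measured compounds shown here, in an assay on HEK293 cells for inhibition of acid ceramidase (Homo sapiens), with a stated time of 10 min (on this read-out higher numbers stand for weaker inhibition and lower numbers for stronger inhibition), compound 1 gives 29 nM, the higher of the two numbers measured so far. The other measured compound, compound 2 `O=C(NCCCCc1ccccc1)n1c(=O)oc2ccc([N+](=O)[O-])cc21`, gives 3 nM in this assay, and that gap lies beyond the usual scatter. The next compound, compound 3 `O=C(NCCCCc1ccccc1)n1c(=O)oc2cc(F)ccc21`, differs from compound 1 by fluoro in place of benzoyl on an aromatic carbon. For the measured compounds named here, no measured pair shows this change, so the step is a matter of expectation: in this assay a modest step of a 1.9-fold lower number from compound 1 to compound 3 (0.29 log units; within the scatter) toward stronger inhibition is expected. Compound 3 is therefore estimated at 15 nM in this assay, within a range of 4 nM to 60 nM.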

Compound 3, half-maximal inhibitory concentration: 31 nM
For compound 3 the middle estimate is 2.1-fold (0.32 log units) below the measured one, within the range that was stated.
By their numbers in this assay, from the lowest: compound 2; then compounds 1 and 3 (each within the scatter of the next).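

Replacing benzoyl with fluoro on this aromatic carbon gives a 1.1-fold higher number from compound 1 to compound 3 (0.03 log units; within the scatter) in this assay, so the assay does not separate the two compounds. At this place, then, the benzoyl group, with its six-membered aromatic ring and carbonyl, can give way to a single fluorine without a step beyond the scatter. No available evidence explains this match.

As far as these compounds go, whether an amine, a carboxylic acid or a methoxy group at this place would also stay within the scatter of compound 1 remains open. So does whether fluoro and benzoyl would also match on another aromatic carbon of the core.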